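The source may report more compounds than this note shows. Statements on the series, on what has been measured and on what is new or still open speak of the compounds shown alone.

In an ADME assay on microsomes from liver (Rattus norvegicus) for metabolic stability (on this read-out higher numbers stand for a longer-lived compound and lower numbers for a shorter-lived compound), compound 1 `Nc1nc(NCCNc2ncc(-c3ncc[nH]3)c(-c3ccc(C(F)(F)F)cc3)n2)ccc1[N+](=O)[O-]` gives > 0.5 h, which is a limit and not a number. Compound 2 `Nc1nc(NCCNc2ncc(-c3ncc[nH]3)c(-c3cc(F)ccc3Cl)n2)ccc1[N+](=O)[O-]` gives > 0.5 h, again only a limit. Among the measured compounds shown here, this is the limit of > 0.5 h in this assay, at which 2 of the 2 values shown sit, so the only measured step is a step that the two limits leave unreadable from compound 1 to compound 2. Compound 3 `Nc1nc(NCCNc2ncc(-c3ncc[nH]3)c(-c3ccc(F)cc3C(F)(F)F)n2)ccc1[N+](=O)[O-]` differs from compound 2 on an aromatic carbon: 4-fluoro-2-(trifluoromethyl)phenyl in place of 2-chloro-5-fluorophenyl on an aromatic carbon. For the measured compounds named here, with no step of readable size to draw on, no clear shift in either direction is expected in this assay, and the expected step is a step that the limit leaves unreadable from compound 2 to compound 3. The estimate for compound 3 is 0.7 h, with an expected range of 0.35 h to 1.5 h.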

Compound 3, half-life: > 0.5 h
Compound 3: no number, only a limit; the forecaster's own chance of this, stated with the estimate: 80%; the middle value does not contradict the limit.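

Compound 1, compound 2 and compound 3 each give only a limit and not a number, so no step between them can be read: the limit of > 0.5 h in this assay, at which 3 of the 3 values shown sit.

Going by these compounds, their actual half-lives stay open, and so does whether exchanging these substituted phenyl groups changes the half-life at all.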